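Chlorine for Methoxy at the Aryl End in Mice

This account rests on a few compounds, and the source may have more. Where it says the series, first, only, none or still open, it means among the compounds named here.

Going by the values given here, the series so far holds three esters built on one shared core. Compound 1 `COc1cc(OC)c(OC)cc1/C=C/COC(=O)/C=C/c1ccc(OC)c(OC)c1`, compound 2 `COc1cc(OC)c(OC)cc1/C=C/COC(=O)/C=C/c1cccc(Br)c1` and compound 3 `COc1cccc(/C=C/C(=O)OC/C=C/c2cc(OC)c(OC)cc2OC)c1` differ only in the aryl group on a double-bonded chain carbon bound to a double-bonded chain carbon. In a functional assay on the whole organism (strain Kunming) with Mus musculus as the target, with a stated time of 0.5 h, at a dose of 100 mg/kg by the intraperitoneal route (on this read-out lower numbers stand for a stronger effect and higher numbers for a weaker effect at the one dose given), compound 1 gives 100%, compound 2 gives 100% and compound 3 gives 100%. Compound 3 thus stands level with compound 1 and compound 2, within the scatter of the read-out. The three steps between them agree: no change at the digits printed from compound 1 to compound 2 (within the scatter), no change at the digits printed from compound 1 to compound 3 (within the scatter) and no change at the digits printed from compound 2 to compound 3 (within the scatter). Neither exchanging the whole aryl group nor trading a methoxy for a bromo at the aryl end has moved the read-out.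

Compound 4 `COc1cc(OC)c(OC)cc1/C=C/COC(=O)/C=C/c1ccc(Cl)cc1` is the next member, and its change from compound 3 is 4-chlorophenyl in place of 3-methoxyphenyl on a double-bonded chain carbon bound to a double-bonded chain carbon. The two steps that bear on it are the aryl swap from compound 1 to compound 2 and the bromo-for-methoxy swap from compound 2 to compound 3, both of which stayed within the scatter. Compound 4 is therefore expected to show no step beyond the scatter, namely no change at the digits printed from compound 3 to compound 4 (within the scatter). Compound 4 is estimated at 100%, with a range from 88% to 100%.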

Compound 4, a percentage reported as activity, at one dose (the size of the read-out at that dose, not a potency): 100%
Compound 4: middle estimate and measured number agree at the digits printed; low and high end bracket the measured number.
By their numbers in this assay, from the lowest: compounds 1, 2, 3 and 4 (each within the scatter of the next).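

With 4-chlorophenyl on a double-bonded chain carbon bound to a double-bonded chain carbon, the series now has a chlorine-bearing aryl group, and this assay shows no change at the digits printed from compound 3 to compound 4 (within the scatter), no change at the digits printed from compound 2 to compound 4 (within the scatter) and no change at the digits printed from compound 1 to compound 4 (within the scatter). Going by these compounds alone, the level result therefore extends to an entering group with 0 hydrogen-bond acceptors, set against the 3-methoxyphenyl group with 1 hydrogen-bond acceptor, and it holds against the 3-bromophenyl and 3,4-dimethoxyphenyl groups as well, with no compound among the four going against it. No supporting evidence bears on why this exchange leaves the read-out level.

The compounds shown leave open whether an aryl group carrying an amine or a carboxylic acid at this place, or a longer chain in place of the aryl group, would shift the read-out from the level shared by compounds 1 to 4. They also leave open whether changes elsewhere on the shared core would move the read-out, since all four compounds keep that core and differ only in the aryl group.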